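Methyl in place of hydrogen on compound 2

The compounds below may be only part of what the source reports. "The series", "measured", "known", "first", "only" and "open" are said of these compounds alone.

Compound 1 `C=C1C[C@]23C[C@@]1(O)CC[C@H]2c1ccc(O)c(C)c1[C@@H]3Cn1cc(-c2ccc(Br)cc2)nn1` and compound 2 `C=C1C[C@]23C[C@@]1(O)CC[C@H]2c1ccc(O)c(C)c1[C@@H]3Cn1cc(-c2ccccc2)nn1` share one core and differ only in a bromo group on an aromatic carbon. In a functional assay on A549 cells (Homo sapiens) for cytotoxicity, read by MTT assay, with a stated time of 4 days (on this read-out higher numbers stand for weaker inhibition and lower numbers for stronger inhibition), compound 1 gives > 20000 nM, which is a limit of the assay rather than a number. In this assay compound 2 likewise gives > 20000 nM, again a limit. The step that the two limits leave unreadable from compound 1 to compound 2 cannot be read, since (the limit of > 20000 nM in this assay, at which 2 of the 2 values shown sit). Compound 2 therefore stands at the limit, with no number to place it more finely. Compound 3 `C=C1C[C@]23C[C@@]1(O)CC[C@H]2c1ccc(O)c(C)c1[C@@H]3Cn1cc(-c2ccc(C)cc2)nn1` is built from compound 2 by methyl in place of hydrogen on an aromatic carbon; in words, methyl in place of hydrogen on an aromatic carbon. Within the data shown here, no measured step reaches beyond the limit, so no step in this assay can be expected beyond the scatter. Compound 3 is estimated at 30000 nM, in a range from 10000 nM to 100000 nM, and will most likely itself be reported only as a limit. The step that the limit leaves unreadable from compound 2 to compound 3 expected from this is small.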

Compound 3, half-maximal inhibitory concentration: > 20000 nM
Compound 3 was reported as a limit; the forecaster's own chance of this, stated with the estimate: 80%; the middle value lies beyond the limit too.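

The steps between compound 1, compound 2 and compound 3 cannot be read, because all three compounds sit at the same limit of this assay: the limit of > 20000 nM in this assay, at which 3 of the 3 values shown sit.

On these data alone, whether bromo, hydrogen and methyl on this aromatic carbon differ at all in their effect on these cells stays open.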